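Cytotoxicity of two analogues and an expected dichlorophenyl variant

The source may report more compounds than this note shows. Statements on the series, on what has been measured and on what is new or still open speak of the compounds shown alone.

Measured compounds:
compound 1, `COc1ccc(C(=O)CSc2nc(Cc3cccc(O)c3)c(C)c(=O)[nH]2)cc1` — 70000 nM
compound 2, `COc1ccc(C(=O)CSc2nc(Cc3cc(C(F)(F)F)cc(C(F)(F)F)c3)c(C)c(=O)[nH]2)cc1` — > 242000 nM

In an ADME assay on MT4 cells (Homo sapiens) for cytotoxicity (a lower number here means that less compound is tolerated, a higher number that more compound is tolerated), compound 1 gives 70000 nM. Compound 2 is reported in this assay only as a limit, > 242000 nM, so no number stands for it. Among the measured compounds shown here, of the two values shown, compound 1 has the only number; among the values shown, one sits at the limit of > 242000 nM in this assay, at which 1 of the 2 values shown sits. For the measured compounds named here, no step between measured compounds that differ in one place is available, so the pair of compound 1 and compound 2 shows only what its two values show.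

Compound 3, `COc1ccc(C(=O)CSc2nc(Cc3c(Cl)cccc3Cl)c(C)c(=O)[nH]2)cc1`, is unmeasured and differs from compound 1 in one place: 2,6-dichlorophenyl in place of 3-hydroxyphenyl on a saturated chain carbon bound to an aromatic carbon. Going by the values given here, with no measured step to lean on, the expected step from compound 1 to compound 3 in this assay is modest and upward, a 1.6-fold higher number from compound 1 to compound 3 (0.20 log units; within the scatter), though a result within the scatter would not surprise. Compound 3 is therefore estimated at 110000 nM, with a range from 40000 nM to 250000 nM.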

Compound 3, half-maximal cytotoxic concentration: > 278000 nM
Compound 3 was reported as a limit (the forecaster's own chance of this, stated with the estimate: 35%); middle value at least 2.5-fold (0.40 log units) from the limit.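

In this assay, among the compounds shown here, putting 2,6-dichlorophenyl in place of 3-hydroxyphenyl on a saturated chain carbon bound to an aromatic carbon gives an at least 3.9-fold higher number from compound 1 to compound 3 (0.59 log units; beyond the scatter), the first step at this position that can be read. Compound 3 is reported only as a limit: the limit of > 278000 nM in this assay, at which 1 of the 3 values shown sits. Compound 2, which also carries no hydroxyl on this ring, is likewise reported only as a limit: the limit of > 242000 nM in this assay, at which 1 of the 3 values shown sits.

How far compound 2 and compound 3 lie past their limits stays open, and the compounds shown do not separate the loss of the hydroxyl from the arrival of the two chlorines. Nor do they tell how this assay would respond to an amine or a carboxylic acid in place of that hydroxyl, or to a plain phenyl at this position.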